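Aryl exchange on the saturated ring carbon: compound 4

The compounds below may be only part of what the source reports. "The series", "measured", "known", "first", "only" and "open" are said of these compounds alone.

All numbers are half-maximal effective concentrations in a functional assay on HEK293 cells for agonist activity at D(4) dopamine receptor (Homo sapiens), read by FLIPR; a higher number here means that more compound is needed for the effect, a lower number that less compound is needed.

compound 3 `Cc1cccc(NC(=O)CN2CCC(c3nccs3)CC2)c1` — 1 nM
compound 1 `CCc1cccc(NC(=O)CN2CCC(c3cccc[n+]3[O-])CC2)c1` — 95 nM
compound 2 `O=C(NCN1CCC(c2cccc[n+]2[O-])CC1)c1ccccc1` — 532 nM

Compound 3 gives the lowest of the three numbers. Within the data shown here, compound 1 sits well above it and compound 2 further still, both beyond the scatter, but each of those pairs differs from compound 3 in more than one place, so no single step is read from them; their two values are simply what they show.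

Compound 4 `Cc1cccc(NC(=O)CN2CCC(c3cccc(F)c3)CC2)c1` differs from compound 3 in one place: 3-fluorophenyl in place of 1,3-thiazol-2-yl on a saturated ring carbon. Among the measured compounds shown here, no measured pair isolates this exchange, so the expected step rests on compound 3 alone, taken as the anchor of the set. The step from compound 3 to compound 4 is expected to be a modest rise in this assay, a 3.0-fold higher number from compound 3 to compound 4 (0.48 log units; beyond the scatter), possibly none beyond the scatter. Compound 4 is therefore estimated at 3 nM, with a range from 0.5 nM to 20 nM.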

Compound 4, half-maximal effective concentration: 512 nM
Beside the measured number, compound 4's estimate is 170-fold (2.23 log units) below it, outside the stated range (above it).
By their numbers in this assay, from the lowest: compound 3; then compound 1; then compounds 4 and 2 (each within the scatter of the next).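

Among these compounds, the saturated ring carbon three ring bonds from the ring nitrogen is very sensitive to the aryl group it carries in this assay with a 510-fold higher number from compound 3 to compound 4 (2.71 log units; beyond the scatter) as the first step that can be read at a single place. The earlier compounds shown here could not show this, since they differ from one another in more than one place, and the size of an exchange at this carbon stood open until this pair. Nothing at hand gives a reason for the step.

This one pair does not separate the departure of 1,3-thiazol-2-yl from the arrival of the six-membered carbon ring or from its fluorine. Unsubstituted phenyl, 2-fluorophenyl or 1,3-oxazol-2-yl on the same carbon of the shared core would bear on that question.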